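The compounds below may be only part of what the source reports. "The series", "measured", "known", "first", "only" and "open" are said of these compounds alone.

Compound 1 `C[C@@H](O)[C@H]1C(=O)N2C(C(=O)O)=C(S[C@@H]3CN[C@H](C(=O)Nc4cccc(C(=O)OCC(F)(F)F)c4)C3)[C@H](C)[C@H]12` carries a trifluoroethyl ester on its aniline side and enters an ADME assay on a cell-free system (plasma, Homo sapiens) for metabolic stability, read by LC-MS, with a stated time of 60 min, at 37 degrees C, tested at 50 uM (a lower number here means that less of the compound is left, a higher number that more of the compound is left), without a number of its own: for compound 1 the result reads "not determined" (no result reported). Two relatives frame the question. Compound 2 `C[C@@H](O)[C@H]1C(=O)N2C(C(=O)OCOC(=O)OC3CCCCC3)=C(S[C@@H]3CN[C@H](C(=O)Nc4cccc(C(=O)O)c4)C3)[C@H](C)[C@H]12` gives 46% in this assay, while compound 3 `C[C@@H](O)[C@H]1C(=O)N2C(C(=O)OCC(F)(F)F)=C(S[C@@H]3CN[C@H](C(=O)Nc4cccc(C(=O)OCC(F)(F)F)c4)C3)[C@H](C)[C@H]12` gives 6%. Compound 4 `Cc1oc(=O)oc1COC(=O)c1cccc(NC(=O)[C@@H]2C[C@H](SC3=C(C(=O)O)N4C(=O)[C@H]([C@@H](C)O)[C@H]4[C@H]3C)CN2)c1` differs from compound 1 by a group of 7 heavy atoms (4 carbon, 3 oxygen; one five-membered aromatic ring with 2 hetero atoms) in place of a group of 4 heavy atoms (1 carbon, 3 fluorine; no ring), on a saturated chain carbon bound to an oxygen next to a carbonyl group. Among the compounds with values here, since compound 1 has no value, no step can be computed; compound 4 is simply expected to sit low in this assay, closer to compound 3 than to compound 2, because compound 3 with its two trifluoroethyl esters shows only 6%. For compound 4 the expected remaining fraction is estimated at 20%, within a range from 3% to 55%.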

Compound 4, percent of the compound remaining: 12%
For compound 4 the middle estimate is 8 percentage points above the measured one, within the range that was stated.
By their numbers in this assay, from the lowest: compounds 3 and 4 (each within the scatter of the next); then compound 2.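

No step can be read between compound 1 and compound 4. The compounds shown leave open what exchanging the trifluoromethyl for the group in compound 4 does in this assay. No evidence at hand bears on this result.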